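From trifluoromethoxy to trifluoromethyl: compound 3 and compound 4

The source may hold more compounds than are shown below. What is called first, only, known or untested is meant among the compounds shown, and "the series" means these compounds.

Compound 1 `Cc1cccc(-c2nc3cc(C)ccc3c(=O)[nH]2)c1`: 11200 nM
Compound 2 `Cc1cccc(-c2nc3ccc(C)cc3c(=O)[nH]2)c1`: > 50000 nM (a limit, not a number)
Compound 3 `CCN(CC)c1ccc2nc(-c3ccccc3OC(F)(F)F)[nH]c(=O)c2c1`: 40 nM

These three compounds were all measured in a functional assay on HeLa cells (Homo sapiens) for cytotoxicity, read by MTT assay, with a stated time of 2 days (a higher number here means a weaker inhibitor, a lower number a stronger inhibitor), and they form the whole of the evidence so far. Compound 3, at 40 nM, holds the lower of the two actual numbers. For the measured compounds named here, the only other number belongs to compound 1, at 11200 nM, which lies far higher. For compound 2 the reading of > 50000 nM is a limit of the assay. Going by the values given here, no two measured compounds differ in one place only, so no measured step is available as a guide.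

The next compound, compound 4 `CCN(CC)c1ccc2nc(-c3ccccc3C(F)(F)F)[nH]c(=O)c2c1`, departs from compound 3 in a single group. Trifluoromethyl stands in place of trifluoromethoxy on an aromatic carbon, ortho to a large group, and the count of that change is trifluoromethyl in place of trifluoromethoxy on an aromatic carbon in full. Among the compounds with values here, the expectation starts from compound 3 at 40 nM and, with only this one group changed, foresees a modest rise in the number in this assay or none beyond the scatter. The expected change is a 2.0-fold higher number from compound 3 to compound 4 (0.30 log units; within the scatter), and this estimate remains uncertain. The estimated value for compound 4 is 80 nM, with an expected range from 15 nM to 450 nM.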

Compound 4, half-maximal inhibitory concentration: 100 nM
Estimate against measurement, compound 4: 1.3-fold (0.10 log units) below, within the range that was stated.
By their numbers in this assay, from the lowest: compound 3; then compound 4; then compound 1. At a limit, above all of these: compound 2.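

For the compounds shown here, compound 3 and compound 4 form the first pair that differ in one place only, so they give the first measured reading of a single change, which in this assay is a 2.5-fold higher number from compound 3 to compound 4 (0.40 log units; beyond the scatter). At this aromatic carbon, ortho to a large group, trifluoromethyl in place of trifluoromethoxy therefore keeps the number of the same general order, which shows that the oxygen of trifluoromethoxy is not required for a reading in this range, although the step is modest and still lies beyond the scatter. Nothing measured among these compounds bears on why the number moves with this change.

The compounds shown test this exchange only once, on a single shared core, so it remains open whether the same step would appear with a different substitution elsewhere on that core. From the compounds shown here alone, it also remains open how the number would respond at this aromatic carbon to a methoxy group, a chlorine atom, an amine or a carboxylic acid.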